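A few compounds are considered here, and "the series" means these few. Any claim that something is new, unique, unknown or untested is made for them only; others in the source may bear on it.

In a functional assay on PC-3 cells (Homo sapiens) for antiproliferative activity, read by MTT assay, with a stated time of 96 h (on this read-out higher numbers stand for weaker inhibition of growth and lower numbers for stronger inhibition of growth), compound 2 `Oc1ccc(Cl)c2ccc(Nc3ccccn3)nc12` gives 1290 nM and stands lowest of the two numbers, while compound 1 `Cc1ccnc(Nc2ccc3cccc(O)c3n2)c1` gives 5840 nM and lies beyond the scatter above it. Compound 3 `Cc1ccnc(Nc2ccc3c(Cl)ccc(O)c3n2)c1` differs from compound 2 by methyl in place of hydrogen on an aromatic carbon on a six-membered aromatic ring with 1 nitrogen, meta to a large group and opposite the ring nitrogen. Within the data shown here, no measured pair isolates this change: compound 1 and compound 2 differ in more than one place. A step within the scatter is expected in this assay with no direction favoured. The estimated step runs a 1.0-fold higher number from compound 2 to compound 3 (0.00 log units; within the scatter) and is expected to stay small. The expected value for compound 3 is 1300 nM (estimated range 500 nM to 3400 nM).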

Compound 3, concentration for 50% growth inhibition: 10200 nM
The estimate for compound 3 lay 7.8-fold (0.89 log units) below the measured number; measured number above the stated range.
By their numbers in this assay, from the lowest: compound 2; then compounds 1 and 3 (each within the scatter of the next).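

In this assay, methyl in place of hydrogen on an aromatic carbon, meta to a large group and opposite the ring nitrogen, gives a 7.9-fold higher number from compound 2 to compound 3 (0.90 log units; beyond the scatter) in the presence of the chloro group, so this position is sensitive to the change. With that methyl in place, adding the chloro group gives only a 1.7-fold higher number from compound 1 to compound 3 (0.24 log units; within the scatter) and so has no clear effect. As far as these compounds go, whether an ethyl group or an amine at this position would be tolerated stays open. No supporting measurement explains the methyl step.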